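A few compounds are considered here, and "the series" means these few. Any claim that something is new, unique, unknown or untested is made for them only; others in the source may bear on it.

Measured so far in a physicochemical assay, with a stated time of 90 min; on this read-out higher numbers stand for an effect only at larger amounts of compound and lower numbers for an effect already at smaller amounts:
compound 1, `C/C(=N\N=C1/SCC(=O)N1Cc1cccc(F)c1)c1cccs1`, gives 1360000 nM;
compound 2, `O=C1CS/C(=N\N=C2CCCC2)N1Cc1ccc(Cl)cc1`, gives 560000 nM;
compound 3, `O=C1CS/C(=N\N=C2CCCC2)N1Cc1ccccc1F`, gives 700000 nM.

Compound 1 stands at the top of these three numbers, but its distance from compound 3 lies within the usual scatter of this assay, so only its separation from compound 2 can be taken as real.

Compound 4, `C/C(=N\N=C1/SCC(=O)N1Cc1cccc(Cl)c1)c1cccs1`, has not yet been measured. It differs from compound 1 in a single place: chloro in place of fluoro on an aromatic carbon. The ring that carries this change is the six-membered aromatic ring of carbon only, and the changed position is meta to a large group.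

Within the data shown here, only one measured step offers any guidance. The step of a 1.3-fold higher number from compound 2 to compound 3 (0.10 log units; within the scatter) also exchanges one halogen-bearing aromatic ring for another, and it stayed within the scatter. Among the measured compounds shown here, that step swaps both the halogen and its position at once, so it does not isolate a chloro-for-fluoro exchange, and no step exists between compound 1 and any other compound. On this thin basis, the expected movement in this assay from compound 1 to compound 4 is a 1.1-fold lower number from compound 1 to compound 4 (0.05 log units; within the scatter), meaning no change beyond the scatter is anticipated. Compound 4 is therefore estimated at 1200000 nM, with a plausible range from 500000 nM to 3000000 nM.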

Compound 4, half-maximal effective concentration: 1160000 nM
Estimate against measurement, compound 4: 1.0-fold (0.01 log units) above, and the stated range covers the measured number.
By their numbers in this assay, from the lowest: compounds 2, 3, 4 and 1 (each within the scatter of the next, the first and the last beyond it).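

In this assay, replacing the 3-fluorophenyl of compound 1 with 3-chlorophenyl gives a 1.2-fold lower number from compound 1 to compound 4 (0.07 log units; within the scatter), so at this place, an aromatic carbon meta to a large group, one halogen can stand in for the other without a change that can be told apart from the scatter. The earlier step from compound 2 to compound 3 altered the halogen and its place together, which left the effect of the halogen alone unseen; this pair holds everything else fixed and changes only that one atom. No measurement at hand explains this result, and it says nothing about why the two halogens read alike.

Fluoro and chloro are the only groups seen at this place, so it remains open whether something other than a halogen, such as an amine, a carboxylic acid or a longer chain, would move the number beyond the scatter. On these data alone, it is also open whether the same chloro-for-fluoro exchange, at this same place, would read alike on the core of compound 2, where the rest of the molecule differs.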